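Notes on the aryl tetrazole series, compound 4

The source may hold more compounds than are shown below. What is called first, only, known or untested is meant among the compounds shown, and "the series" means these compounds.

The series shares one core, seen in compound 1 `Cc1cc(NC(=O)Cn2nnc(-c3ccccc3)n2)n(C2CCCCC2)n1`, compound 2 `Cc1cc(NC(=O)Cn2nnc(-c3cccnc3)n2)n(C2CCCCC2)n1` and compound 3 `Cc1cc(NC(=O)Cn2nnc(-c3ccc(Cl)c(Cl)c3)n2)n(C2CCCCC2)n1`; the three differ only in the aromatic group on the five-membered ring. In an assay on HEK293 cells for activation of Kir3.1/Kir3.2 (Homo sapiens), read by thallium flux (a lower number here means that less compound is needed, a higher number that more compound is needed for the effect), compound 1 gives 96 nM, compound 2 gives 1930 nM and compound 3 gives 1220 nM. Compound 3 thus stands second highest of the three numbers. Its nearest neighbour is compound 2, with a 1.6-fold lower number from compound 2 to compound 3 (0.20 log units; within the scatter), while the gap to compound 1 is large, a 13-fold higher number from compound 1 to compound 3 (1.10 log units; beyond the scatter), as is the parallel step a 20-fold higher number from compound 1 to compound 2 (1.30 log units; beyond the scatter).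

Compound 4 `Cc1cc(NC(=O)Cn2nnc(-c3ccc(F)cc3)n2)n(C2CCCCC2)n1` differs from compound 3 in one place: 4-fluorophenyl in place of 3,4-dichlorophenyl on an aromatic carbon. Within the data shown here, the steps that bear on this are the two departures from phenyl, a 13-fold higher number from compound 1 to compound 3 (1.10 log units; beyond the scatter) and a 20-fold higher number from compound 1 to compound 2 (1.30 log units; beyond the scatter), both large rises. Compound 4 moves back toward the phenyl of compound 1 while keeping a single halogen, so in this assay the number for compound 4 is expected to fall back toward that of compound 1, a step estimated as a 6.1-fold lower number from compound 3 to compound 4 (0.79 log units; beyond the scatter). Among the measured compounds shown here, no measured compound carries a lone fluorine, so the size rests on interpolation between compound 1 and compound 3. The estimate for compound 4 in this assay is 200 nM, with a range from 60 nM to 700 nM.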

Compound 4, half-maximal effective concentration: 180 nM
For compound 4 the middle estimate is 1.1-fold (0.05 log units) above the measured one, within the range that was stated.
By their numbers in this assay, from the lowest: compounds 1 and 4 (each within the scatter of the next); then compounds 3 and 2 (each within the scatter of the next).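

In this assay, the phenyl on an aromatic carbon of a five-membered aromatic ring with 4 nitrogen proves able to carry a substituent without a clear penalty: fluoro in place of hydrogen gives a step within the scatter (a 1.9-fold higher number from compound 1 to compound 4 (0.27 log units; within the scatter)). This separates the result from both earlier departures from phenyl, since 4-fluorophenyl in place of 3,4-dichlorophenyl gives a clear drop (a 6.8-fold lower number from compound 3 to compound 4 (0.83 log units; beyond the scatter)) and 4-fluorophenyl in place of pyridin-3-yl gives a larger one (an 11-fold lower number from compound 2 to compound 4 (1.03 log units; beyond the scatter)). The large rises seen with compound 2 and compound 3 therefore belong to those particular groups and not to every change from phenyl, and a halogen as such is not enough to produce such a rise, as compound 4 stands against that reading.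

Still open, on these data alone, is how the number responds to a single chlorine, a methoxy group, an amine or a carboxylic acid on this phenyl, and whether the loss with 3,4-dichlorophenyl follows from the number of halogens or from their kind. Nothing measured here accounts for the differences among these groups.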